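Trifluoromethyl for Methyl on the Sulfonamide Ring

The compounds below may be only part of what the source reports. "The series", "measured", "known", "first", "only" and "open" are said of these compounds alone.

Compound 1 `O=C(Nc1ccc(-c2noc(-c3cccc(NS(=O)(=O)c4ccccc4)c3)n2)c(Cl)c1)c1cccnc1`: > 10000 nM
Compound 2 `NS(=O)(=O)c1ccc(S(=O)(=O)Nc2cccc(-c3nc(-c4ccc(NC(=O)c5cccnc5)cc4Cl)no3)c2)cc1`: > 10000 nM
Compound 3 `Cc1ccc(S(=O)(=O)Nc2cccc(-c3nc(-c4ccc(NC(=O)c5cccnc5)cc4Cl)no3)c2)cc1`: > 10000 nM

These values come from a functional assay on MDA-MB-231 cells (Homo sapiens) for antiproliferative activity, read by MTT assay, with a stated time of 72 h; on this read-out higher numbers stand for weaker inhibition and lower numbers for stronger inhibition. Each value is a limit of the assay and not a number. Compound 3 therefore stands at the limit of > 10000 nM in this assay, at which 3 of the 3 values shown sit. The steps between the measured compounds, a step that the two limits leave unreadable from compound 1 to compound 2, a step that the two limits leave unreadable from compound 1 to compound 3 and a step that the two limits leave unreadable from compound 2 to compound 3, cannot be read in size or direction. Compound 4 `O=C(Nc1ccc(-c2noc(-c3cccc(NS(=O)(=O)c4ccc(C(F)(F)F)cc4)c3)n2)c(Cl)c1)c1cccnc1` differs from compound 3 by trifluoromethyl in place of methyl on an aromatic carbon. With no readable step to lean on, no shift beyond the scatter can be expected, and compound 4 is expected to sit where compound 3 sits, with an expected step that the limit leaves unreadable from compound 3 to compound 4. Compound 4 is estimated at 15000 nM, between 4000 nM and 60000 nM, most likely reported again as a limit.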

Compound 4, half-maximal inhibitory concentration: > 10000 nM
Compound 4: no number, only a limit; the forecaster's own chance of this, stated with the estimate: 80%; the middle value lies beyond the limit too.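

Compound 4 shares one assay limit with compound 1, compound 2 and compound 3, so no step to compound 4 can be read: the limit of > 10000 nM in this assay, at which 4 of the 4 values shown sit.

Whether any group on the sulfonamide ring can shift activity in this assay stays open, as none of these compounds gives a number.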